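The source may hold more compounds than are shown below. What is called first, only, known or untested is meant among the compounds shown, and "the series" means these compounds.

Compound 1, `Clc1ccc(Cn2c(CCc3c[nH]cn3)nnc2Cc2c[nH]c3ccccc23)cc1Cl`: in an assay on cells for displacement of a labelled ligand from somatostatin receptor type 4 (Homo sapiens), with a stated time of 90 min (a higher number here means a weaker inhibitor, a lower number a stronger inhibitor), compound 1 gives > 10000 nM, a limit of the assay.
Compound 2, `c1ccc(Cn2c(Cc3c[nH]c4ccccc34)nnc2C2CCNCC2)cc1`: compound 2 gives > 10000 nM, also a limit.
Compound 3, `NCCCc1nnc(CCc2c[nH]c3ccccc23)n1Cc1ccccc1`: compound 3 gives < 10000 nM, which is again a limit and not a number.

Compound 3 therefore has no exact figure in this assay; it sits at the limit of < 10000 nM in this assay, at which 1 of the 3 values shown sits, whereas the other two compounds sit at the limit of > 10000 nM in this assay, at which 2 of the 3 values shown sit. The next compound, compound 4, `c1ccc(Cn2c(CCc3c[nH]c4ccccc34)nnc2C2CCNCC2)cc1`, has not yet been measured. It differs from compound 3 in one place: piperidin-4-yl in place of 3-aminopropyl on an aromatic carbon. Within the data shown here, no measured step covers this change. Compound 2 also carries a piperidin-4-yl group, and its value in this assay is a limit. On that basis a step toward weaker binding, rather than none beyond the scatter, is expected from compound 3 to compound 4, estimated as a step that the limit leaves unreadable from compound 3 to compound 4. For compound 4 the estimate in this assay is 8000 nM, with a range from 2000 nM to 30000 nM, and a sizeable chance that only a limit is reported.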

Compound 4, inhibition constant: > 10000 nM
Compound 4: a limit, no number (the forecaster's own chance of this, stated with the estimate: 60%); at least 1.2-fold (0.09 log units) between middle value and limit.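

Among these compounds, compound 3 and compound 4 are the first pair to differ in one place, so the exchange of 3-aminopropyl for piperidin-4-yl on an aromatic carbon can be looked at alone. In this assay compound 4 gives > 10000 nM, a limit and not a number. The change therefore gives a number no lower from compound 3 to compound 4 (the limit leaves the size open). Compound 4 joins the compounds held at the upper limit: the limit of > 10000 nM in this assay, at which 3 of the 4 values shown sit.

From the compounds shown here alone, compound 3 has only a limit too, so how strongly the 3-aminopropyl compound binds remains unknown. The compounds shown also leave open whether a longer chain ending in an amine, or a carboxylic acid, on this aromatic carbon would give a number in this assay.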